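The source may report more compounds than this note shows. Statements on the series, on what has been measured and on what is new or still open speak of the compounds shown alone.

In a functional assay on HL-60 cells (Homo sapiens) for inhibition, read by MTT assay, with a stated time of 72 h (a lower number here means a stronger inhibitor, a higher number a weaker inhibitor), compound 1 `O=C1C=C[C@@H](OC2CCCC2)O[C@@H]1CO` gives 4200 nM and compound 2 `C#CCO[C@@H]1C=CC(=O)[C@@H](CO)O1` gives 9300 nM, the higher of the two numbers. Compound 3 `C=CCO[C@@H]1C=CC(=O)[C@@H](CO)O1` differs from compound 2 by vinyl in place of ethynyl on a saturated chain carbon bound to an oxygen on a saturated carbon. Among the compounds with values here, one measured step bears on this: a 2.2-fold higher number from compound 1 to compound 2 (0.35 log units; beyond the scatter), a modest one that replaces cyclopentyl with propargyl. The present change is a smaller one, so no step beyond the scatter is expected: a 1.2-fold lower number from compound 2 to compound 3 (0.07 log units; within the scatter) is the estimated step. For compound 3 the expected value is 8000 nM, with an estimated range of 3500 nM to 18000 nM.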

Compound 3, half-maximal inhibitory concentration: 4900 nM
For compound 3 the middle estimate is 1.6-fold (0.21 log units) above the measured one; the measured number falls inside the stated range.
By their numbers in this assay, from the lowest: compounds 1, 3 and 2 (each within the scatter of the next, the first and the last beyond it).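

In this assay the change of ethynyl to vinyl on a saturated chain carbon bound to an oxygen on a saturated carbon gives a 1.9-fold lower number from compound 2 to compound 3 (0.28 log units; within the scatter), so this change does not separate the two compounds. Allyl in place of cyclopentyl gives a 1.2-fold higher number from compound 1 to compound 3 (0.07 log units; within the scatter), so allyl, unlike propargyl, cannot be told apart from cyclopentyl on this oxygen. Nothing available here accounts for these numbers. Still open, on these data alone, is how a saturated propyl chain, a longer chain or an amine on this oxygen would read in this assay.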